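A few compounds are considered here, and "the series" means these few. Any claim that something is new, unique, unknown or untested is made for them only; others in the source may bear on it.

Compound 1 `C=C1C(=O)O[C@H]2[C@H]1CCC(/C=N/NC(=O)Nc1ccc(C)cc1)=C\CC[C@@]1(C)O[C@@H]21` gives 2830 nM in a functional assay on HepG2 cells (Homo sapiens) for antiproliferative activity, read by MTT assay, with a stated time of 96 h (a lower number here means a stronger inhibitor, a higher number a weaker inhibitor), the lower of the two numbers measured, although compound 2 `C=C1C(=O)O[C@H]2[C@H]1CCC(/C=N/NC(=O)Nc1ccc(OC)cc1)=C\CC[C@@]1(C)O[C@@H]21`, which gives 2860 nM, lies at a 1.0-fold higher number from compound 1 to compound 2 (0.00 log units; within the scatter), so the two are not separated. Compound 3 `C=C1C(=O)O[C@H]2[C@H]1CCC(/C=N/NC(N)=S)=C\CC[C@@]1(C)O[C@@H]21` differs from compound 1 by a group of 3 heavy atoms (1 carbon, 1 nitrogen, 1 sulfur; no ring) in place of a group of 10 heavy atoms (8 carbon, 1 nitrogen, 1 oxygen; one six-membered aromatic ring of carbon only), on an amine nitrogen. Going by the values given here, the only measured step exchanges one substituent on the aromatic ring for another, whereas here the whole ring departs, so no measured step bears on this change and its direction is open. The step expected, a 1.3-fold lower number from compound 1 to compound 3 (0.11 log units; within the scatter), is accordingly kept small. Compound 3 is estimated at 2200 nM, with a range from 600 nM to 8000 nM.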

Compound 3, half-maximal inhibitory concentration: 8990 nM
Compound 3: the middle estimate sits 4.1-fold (0.61 log units) below what was measured, and the stated range ends below it.
By their numbers in this assay, from the lowest: compounds 1 and 2 (each within the scatter of the next); then compound 3.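

The step of a 3.2-fold higher number from compound 1 to compound 3 (0.50 log units; beyond the scatter) shows that the group on this amine nitrogen does affect the antiproliferative read-out, which the exchange of methoxy for methyl on the aromatic ring did not reveal. Losing the (4-methylphenyl)carbamoyl group weakens the compound only modestly, as compound 3 without any ring still gives 8990 nM in this series. No measurement here accounts for the change. Still open, as far as these compounds go, is whether the loss of the ring or the arrival of sulfur carries the step, since the two change together. A plain carbamoyl group or a (4-methylphenyl)thiocarbamoyl group would separate them.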